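The compounds below may be only part of what the source reports. "The series", "measured", "known", "first", "only" and "open" are said of these compounds alone.

Measured compounds in a functional assay on Ramos cells (Homo sapiens) for antiproliferative activity; on this read-out lower numbers stand for stronger inhibition and higher numbers for weaker inhibition:
compound 1 `Nc1ncnc2c1c(-c1cc3ccccc3o1)cn2[C@H]1CCN(C[C@H]2CO2)C1`: 1650 nM
compound 3 `Nc1ncnc2c1c(-c1cnc3[nH]ccc3c1)cn2[C@H]1CCN(C[C@@H]2CO2)C1`: 4650 nM
compound 2 `Nc1ncnc2c1c(-c1ccc(Oc3ccccc3)cc1)cn2[C@H]1CCN(C[C@H]2CO2)C1`: a limit only

Compound 1 and compound 3 give numbers. For compound 2 only a limit of the assay is known, > 50000 nM. Compound 2 therefore stands at the limit of > 50000 nM in this assay, at which 1 of the 3 values shown sits, with no number to rank against the other two. Compound 4 `Nc1ncnc2c1c(-c1ccc(Oc3ccccc3)cc1)cn2C[C@H]1CCCN1C[C@@H]1CO1` is not yet measured. It differs from compound 2 in one place: (1-((oxiran-2-yl)methyl)pyrrolidin-2-yl)methyl in place of 1-((oxiran-2-yl)methyl)pyrrolidin-3-yl on an aromatic nitrogen. Going by the values given here, no measured pair in the set covers this change, so nothing measured fixes the size of the step, and compound 2 sitting at the limit gives no anchor for its direction. Compound 4 is expected to remain weak, the expected step being an at least 1.2-fold lower number from compound 2 to compound 4 (0.09 log units; that floor lies within the scatter). The estimate for compound 4 is 40000 nM, within 8000 nM to 200000 nM, with a real chance that only a limit is reported again.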

Compound 4, half-maximal inhibitory concentration: 8520 nM
Beside the measured number, compound 4's estimate is 4.7-fold (0.67 log units) above it, and the stated range covers the measured number.
By their numbers in this assay, from the lowest: compound 1; then compounds 3 and 4 (each within the scatter of the next). At a limit, above all of these: compound 2.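

On the aromatic nitrogen, (1-((oxiran-2-yl)methyl)pyrrolidin-2-yl)methyl in place of 1-((oxiran-2-yl)methyl)pyrrolidin-3-yl gives an at least 5.8-fold lower number from compound 2 to compound 4 (0.76 log units; beyond the scatter) in this assay, the first step read at this position. Of the two compounds, only compound 4 gives a number. Compound 2 stands at a limit, so the step is only a bound: the limit of > 50000 nM in this assay, at which 1 of the 4 values shown sits.

Still open, from the compounds shown here alone, is whether a piperidine ring or a longer chain at this position would shift the number further. Also open, going by these compounds, is whether the oxirane matters, which an acrylamide in its place would test.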